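This account rests on a few compounds, and the source may have more. Where it says the series, first, only, none or still open, it means among the compounds named here.

Of the compounds shown here, two built on one shared core have so far been tested in a functional assay on HEL cells (Homo sapiens) for cytotoxicity; a higher number here means that more compound is tolerated, a lower number that less compound is tolerated. Compound 1, `CCC(C)C1NC(=O)N(C2CCCCC2)C1=O`, gives > 100 ug/mL, which is a limit of the assay rather than a measured number. Compound 2, `CCC(C)C1NC(=O)N(C2CCCC2)C1=O`, likewise gives > 100 ug/mL in this assay, again a limit and not a number. Compound 2 therefore stands at the limit of > 100 ug/mL in this assay, at which 2 of the 2 values shown sit; neither value shown reaches a cytotoxic concentration within the range tested.

The next compound, compound 3, is `O=C1NC(c2ccccc2)C(=O)N1C1CCCC1`. Its difference from compound 2 is phenyl in place of sec-butyl on a saturated ring carbon. Among the measured compounds shown here, no measured step between two compounds exists here to show what such an exchange does to tolerance in this assay; the only guide is that both compounds measured so far sit at the limit. The expected step is therefore a number no higher from compound 2 to compound 3 (the limit leaves the size open), that is, none beyond the scatter. Compound 3 is accordingly estimated to give about 100 ug/mL in this assay, with a range from 50 ug/mL to 200 ug/mL, and most probably the result will again be reported as a limit rather than as a number.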

Compound 3, minimum cytotoxic concentration: >= 20 ug/mL
Compound 3: no number, only a limit; the forecaster's own chance of this, stated with the estimate: 85%; the middle value lies beyond the limit too.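

In this assay, among the compounds shown here, compound 2 and compound 3 are both reported only as limits, not as numbers, so phenyl in place of sec-butyl gives no step that can be read between them. The compounds shown leave open what concentration becomes cytotoxic with either group, and whether the two groups differ at all.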